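The source may hold more compounds than are shown below. What is called first, only, known or untested is meant among the compounds shown, and "the series" means these compounds.

Values in an assay on CHO T-rex cells for antagonist activity at transient receptor potential cation channel subfamily M member 8 (Homo sapiens), read by calcium flux, with a stated time of 20 min; on this read-out lower numbers stand for stronger inhibition and higher numbers for weaker inhibition:
compound 1 `C[C@H](c1ccc(F)cc1)N(Cc1cccc(C(=O)O)n1)C(=O)c1cnc2ccccc2c1`, 1160 nM
compound 2 `C[C@H](c1ccc(F)cc1)N(Cc1cc(C(=O)O)ccc1F)C(=O)c1cnc2ccccc2c1`, 446 nM
compound 3 `C[C@H](c1ccc(F)cc1)N(Cc1cccc(CC(=O)O)c1)C(=O)c1cnc2ccccc2c1`, > 3240 nM

Compound 3 stands at the top of this small set: its entry is a limit of this assay, not a number (the limit of > 3240 nM in this assay, at which 1 of the 3 values shown sits). The steps of an at least 2.7-fold higher number from compound 1 to compound 3 (0.44 log units; beyond the scatter) and an at least 7.2-fold higher number from compound 2 to compound 3 (0.86 log units; beyond the scatter) are therefore lower bounds. Compound 4 `C[C@H](c1ccc(F)cc1)N(Cc1cccc(-c2nn[nH]n2)c1)C(=O)c1cnc2ccccc2c1` differs from compound 3 by 2H-tetrazol-5-yl in place of carboxymethyl on an aromatic carbon. Among the measured compounds shown here, no measured step changes this group in the same way. The two compounds that carry a carboxy group directly on the aromatic ring, compound 1 and compound 2, gave numbers, whereas compound 3, with the carboxymethyl, gave only a limit. Compound 4 again places its group directly on the ring carbon, so a downward step an at least 2.1-fold lower number from compound 3 to compound 4 (0.33 log units; beyond the scatter) is expected, with real uncertainty. Compound 4 is estimated at 1500 nM, between 400 nM and 6000 nM.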

Compound 4, half-maximal inhibitory concentration: 1610 nM
Beside the measured number, compound 4's estimate is 1.1-fold (0.03 log units) below it; measured number inside the range.
By their numbers in this assay, from the lowest: compound 2; then compounds 1 and 4 (each within the scatter of the next). At a limit, above all of these: compound 3.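

Compound 4 shows that a group other than a carboxy group, set directly on the aromatic ring, can also return a number in this assay. Against the carboxymethyl the change reads as an at least 2.0-fold lower number from compound 3 to compound 4 (0.30 log units; that floor lies within the scatter), a bound and no more, since compound 3 sits at a limit: the limit of > 3240 nM in this assay, at which 1 of the 4 values shown sits. The tetrazole gives a 1.4-fold higher number from compound 1 to compound 4 (0.14 log units; within the scatter), level with the 6-carboxypyridin-2-yl, but a 3.6-fold higher number from compound 2 to compound 4 (0.56 log units; beyond the scatter), short of the 5-carboxy-2-fluorophenyl.

Open, as far as these compounds go, is how a sulfonamide or a hydroxamic acid would stand in this place, and whether a fluorine on the ring of compound 4 would move its number.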